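The source may hold more compounds than are shown below. What is called first, only, known or untested is meant among the compounds shown, and "the series" means these compounds.

In a functional assay on BSC-1 cells (Cercopithecidae) for cytotoxicity (on this read-out higher numbers stand for weaker inhibition and lower numbers for stronger inhibition), compound 1 `CSc1nc(N)c2ccn(COCCO)c2n1` gives > 100000 nM, which is a limit of the assay and not a number. Compound 2 `CS(=O)(=O)c1nc(N)c2ccn(COCCO)c2n1` likewise gives > 100000 nM, again only a limit. Going by the values given here, the single measured step, a step that the two limits leave unreadable from compound 1 to compound 2, thus offers no readable size, and the only evidence is the limit of > 100000 nM in this assay, at which 2 of the 2 values shown sit. Compound 3 `COc1nc(N)c2ccn(COCCO)c2n1` differs from compound 2 by methoxy in place of methylsulfonyl on an aromatic carbon. With no readable step to draw on, no change beyond the scatter is expected in either direction. Compound 3 is therefore estimated at 150000 nM, between 50000 nM and 500000 nM, an expected step that the limit leaves unreadable from compound 2 to compound 3.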

Compound 3, half-maximal inhibitory concentration: > 100000 nM
Compound 3: a limit, no number; the forecaster's own chance of this, stated with the estimate: 85%; the middle value does not contradict the limit.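

No step can be read among compound 1, compound 2 and compound 3, because all three give only a limit and no number: the limit of > 100000 nM in this assay, at which 3 of the 3 values shown sit.

The compounds shown leave open whether methylsulfanyl, methylsulfonyl and methoxy differ at all in this assay.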